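A few compounds are considered here, and "the series" means these few. Any claim that something is new, unique, unknown or untested is made for them only; others in the source may bear on it.

Measured compounds:
- compound 1 `C=CCO/N=C/c1c(N)ncnc1Oc1ccc2[nH]c(C)cc2c1F`: 21 nM
- compound 2 `CO/N=C/c1c(N)ncnc1Oc1ccc2[nH]cc(C)c2c1`: 132 nM

In a functional assay on A-375 cells (Homo sapiens) for antiproliferative activity (on this read-out lower numbers stand for stronger inhibition and higher numbers for weaker inhibition), compound 1 gives 21 nM, the lowest of the two numbers shown. Compound 2 gives 132 nM, a gap beyond the scatter. The unmeasured compound 3 `COCCCO/N=C/c1c(N)ncnc1Oc1ccc2[nH]c(C)cc2c1F` keeps the core of compound 1 and differs only in the chain on the oxygen: 2-methoxyethyl in place of vinyl on a saturated chain carbon bound to an oxygen on an unsaturated carbon. Among the measured compounds shown here, no measured pair shows this change, so its effect is unknown. In this assay the expected step is a 1.4-fold higher number from compound 1 to compound 3 (0.15 log units; within the scatter), within the scatter in either direction. Compound 3 is estimated at 30 nM, with a range of 10 nM to 90 nM.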

Compound 3, half-maximal inhibitory concentration: 300 nM
Compound 3: middle estimate off by 10-fold (1.00 log units), on the low side; the whole stated range lies below it.
By their numbers in this assay, from the lowest: compound 1; then compound 2; then compound 3.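

In this assay, the chain on the oxygen proves sensitive: 2-methoxyethyl in place of vinyl on a saturated chain carbon bound to an oxygen gives a 14-fold higher number from compound 1 to compound 3 (1.15 log units; beyond the scatter) with the shared core unchanged. This single pair combines a longer chain, the loss of the double bond and an added oxygen, so these cannot be separated. Nothing available explains the step.

Open, going by these compounds, is whether a plain butyl chain, without the oxygen, stays close to compound 1. Also open, on these data alone, is how an amine or a hydroxyl at the chain end would read.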